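Piperidin-1-yl for (pyridin-2-yl)oxy: working notes on a short series

This account rests on a few compounds, and the source may have more. Where it says the series, first, only, none or still open, it means among the compounds named here.

- Compound 1 `OC[C@H]1O[C@@H](n2cnc3c(Cn4ccc5ccccc54)ncnc32)[C@H](O)[C@@H]1O` gives 5700 nM
- Compound 2 `OC[C@H]1O[C@@H](n2cnc3c(COc4ccccn4)ncnc32)[C@H](O)[C@@H]1O` gives 12000 nM

For the measured compounds named here, in a functional assay on HL-60 cells (Homo sapiens) for inhibition, with a stated time of 72 h (on this read-out higher numbers stand for weaker inhibition and lower numbers for stronger inhibition), compound 2 holds the higher of the two numbers (12000 nM) and its only neighbour is compound 1 (5700 nM). Going by the values given here, the one measured step is a 2.1-fold higher number from compound 1 to compound 2 (0.32 log units; beyond the scatter) and it is modest. It exchanged 1H-indol-1-yl for (pyridin-2-yl)oxy on a saturated chain carbon bound to an aromatic carbon.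

Compound 3 `OC[C@H]1O[C@@H](n2cnc3c(CN4CCCCC4)ncnc32)[C@H](O)[C@@H]1O` has not been measured. It differs from compound 2 by piperidin-1-yl in place of (pyridin-2-yl)oxy on a saturated chain carbon bound to an aromatic carbon and the change sits at that same place, with piperidin-1-yl in place of (pyridin-2-yl)oxy. Among the compounds with values here, neither measured compound carries a non-aromatic ring there, so the direction remains open and the single step above is the only guide to size. A step no larger than that one is expected in this assay with a slight lean towards a lower number. The estimated change is a 1.3-fold lower number from compound 2 to compound 3 (0.12 log units; within the scatter) and so no step beyond the scatter is expected. Compound 3 is estimated at 9000 nM (expected range 2500 nM to 30000 nM).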

Compound 3, half-maximal inhibitory concentration: 6900 nM
For compound 3 the middle estimate is 1.3-fold (0.12 log units) above the measured one, within the range that was stated.
By their numbers in this assay, from the lowest: compounds 1, 3 and 2 (each within the scatter of the next, the first and the last beyond it).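

Working notes, continued. In this assay, piperidin-1-yl puts the first non-aromatic ring in the series on the saturated chain carbon bound to an aromatic carbon, and the step reads as a 1.7-fold lower number from compound 2 to compound 3 (0.24 log units; within the scatter) and, against the other measured group, as a 1.2-fold higher number from compound 1 to compound 3 (0.08 log units; within the scatter). For the compounds shown here, compound 3 therefore lies within the scatter of both compounds that carry an aromatic ring at this place, which means that, across these three compounds, neither an aromatic ring nor the oxygen of (pyridin-2-yl)oxy is needed for a number in this range, while the only step beyond the scatter remains a 2.1-fold higher number from compound 1 to compound 2 (0.32 log units; beyond the scatter). No supporting data accompany these values.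

All three groups shown are ring groups on that one carbon, and the flat response holds only for them. As far as these compounds go, what a morpholin-4-yl ring, an open-chain dimethylamino group, a carboxylic acid or a longer chain would do at this place stays open, as does whether a group without any ring could hold a number in this range in this assay.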